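From Benzyl to 3-Cyanophenyl on a Shared Core

A few compounds are considered here, and "the series" means these few. Any claim that something is new, unique, unknown or untested is made for them only; others in the source may bear on it.

Measured in a functional assay on T98G cells (Homo sapiens) for inhibition, read by MTT assay, with a stated time of 72 h; on this read-out lower numbers stand for stronger inhibition and higher numbers for weaker inhibition:
- compound 1 `CC1(C)CC(NC(=S)NCc2ccccc2)c2cc(F)ccc2O1`: 40000 nM
- compound 2 `O=[N+]([O-])c1ccc(NC(=S)NCc2cccc(Cl)c2)cc1`: 20000 nM

Compound 1 and compound 2 lie within the usual scatter of each other, so neither stands apart. Compound 3 `CC1(C)CC(NC(=S)Nc2cccc(C#N)c2)c2cc(F)ccc2O1` keeps the core of compound 1 but carries 3-cyanophenyl in place of benzyl on an amide-type nitrogen. Among the measured compounds shown here, no measured pair shows this change alone. In this assay only a small shift toward lower numbers is therefore expected, one that may not clear the scatter. The expected step is a 1.8-fold lower number from compound 1 to compound 3 (0.26 log units; within the scatter). For compound 3 the estimated value is 22000 nM, with an expected range of 7000 nM to 60000 nM.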

Compound 3, half-maximal inhibitory concentration: 39000 nM
The estimate for compound 3 lay 1.8-fold (0.25 log units) below the measured number; the measured number falls inside the stated range.
By their numbers in this assay, from the lowest: compounds 2, 3 and 1 (each within the scatter of the next).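

In this assay, among the compounds shown here, the shared core carrying 3-cyanophenyl in place of benzyl on the amide-type nitrogen gives a 1.0-fold lower number from compound 1 to compound 3 (0.01 log units; within the scatter), the first direct reading of this change. At this place, then, the exchange of benzyl for 3-cyanophenyl, which brings in a nitrile, does not separate compound 3 from compound 1. No measurement available here offers a reason for this result.

Still open, as far as these compounds go, is whether a carboxylic acid or an amine on that phenyl ring, or a longer chain in place of benzyl, would move the number beyond the scatter.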